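This account rests on a few compounds, and the source may have more. Where it says the series, first, only, none or still open, it means among the compounds named here.

Measured so far:
compound 1 `FC(F)(F)c1cc(NC[C@H]2CCCN2)c2cn[nH]c2c1` gives 55%
compound 2 `O=[N+]([O-])c1cccc(CNc2cc(Br)cc3[nH]ncc23)c1` gives 91%
compound 3 `O=[N+]([O-])c1ccccc1CNc1cccc2[nH]ncc12` gives 45%

In an assay for inhibition of Tryptophan 2,3-dioxygenase (Homo sapiens), with stated times of 10 min and 60 min, tested at 10 uM (a lower number here means a weaker effect, a higher number a stronger effect of the compound at the concentration tested), compound 3 stands lowest of the three numbers. Its nearest neighbour is compound 1, whose value lies within the usual scatter of the value of compound 3, so no order between these two can be claimed. Compound 2 lies far beyond the scatter above compound 3 and is clearly the stronger of that pair. Compound 3 carries an unsubstituted shared core with a nitro group on the benzyl ring; compound 1 and compound 2 each carry an additional group on the core, trifluoromethyl and bromine.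

Compound 4 `N#Cc1cc(NCc2ccccc2[N+](=O)[O-])c2cn[nH]c2c1` has not yet been measured. It differs from compound 3 in one place: cyano in place of hydrogen on an aromatic carbon

No measured pair shows this particular change, so the direction rests only on the three numbers shown. Since the two compounds carrying a group on the core give higher numbers than compound 3, compound 4 is expected to gain somewhat in this assay, by a step of a number 20 percentage points higher from compound 3 to compound 4 (beyond the scatter) in this assay, beyond the scatter but modest. The expected value for compound 4 is 65%, with a range from 42% to 88%.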

Compound 4, a percentage reported as inhibition, at one concentration (the size of the read-out at that concentration, not a potency): 22%
For compound 4 the middle estimate is 43 percentage points above the measured one; the measured number lies below the stated range.
By their numbers in this assay, from the lowest: compound 4; then compounds 3 and 1 (each within the scatter of the next); then compound 2.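

In this assay, within the data shown here, the pair gives the first direct reading at this position: cyano in place of hydrogen on an aromatic carbon of the shared core, meta to a large group, gives a number 23 percentage points lower from compound 3 to compound 4 (beyond the scatter) and so a modest loss. Among these compounds, this shows that the position is not indifferent to what it carries and that a group placed there can lower the inhibition seen at the concentration tested, something the earlier compounds could not show, as no two of them differed in only one place. Nothing among the data shown accounts for this loss.

The compounds shown leave open whether the loss belongs to cyano itself or would also follow from other groups on the same carbon, such as a fluorine, a methyl group, a methoxy group or an amine. They also leave open whether cyano at this position would lower the number to a similar extent on a compound with a different side chain, such as that of compound 1.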